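Fluoro on the phenoxy ester: from compound 3 to compound 4

The compounds below may be only part of what the source reports. "The series", "measured", "known", "first", "only" and "open" are said of these compounds alone.

Three esters of the shared core have been run in a functional assay on HT-1080 cells (Homo sapiens), read by transwell migration, with a stated time of 24 h, tested at 1 uM; on this read-out higher numbers stand for a weaker effect at the one concentration tested and lower numbers for a stronger effect. Compound 1 `O=C(Oc1cccc(F)c1)c1cc2cc([N+](=O)[O-])ccc2oc1=O` gives 53.6% in this assay, and compound 2 `NCc1ccc2oc(=O)c(C(=O)Oc3cccc(F)c3)cc2c1` gives 45.3%; the step of a number 8.3 percentage points lower from compound 1 to compound 2 (within the scatter) stays within the scatter. Compound 3 `CC(=O)NCc1ccc2oc(=O)c(C(=O)Oc3ccccc3)cc2c1` gives 63.5%, the highest of the three numbers; its nearest neighbour on the numbers is compound 1, separated by a gap within the scatter, and its furthest is compound 2, separated by a gap beyond the scatter.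

Compound 4 `CC(=O)NCc1ccc2oc(=O)c(C(=O)Oc3cccc(F)c3)cc2c1` differs from compound 3 by fluoro in place of hydrogen on an aromatic carbon. Going by the values given here, no measured pair differs in this way alone: the single measured step, from compound 1 to compound 2, exchanges a different group, and compounds 1 and 2 both already carry the fluoro that enters here. Nothing measured therefore bears on the size of this step, and on that basis no change beyond the scatter in this assay is expected. Compound 4 is expected to give 60% in this assay, within 45% to 75%. That amounts to an expected step of a number 3.5 percentage points lower from compound 3 to compound 4 (within the scatter).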

Compound 4, a percentage reported as activity, at one concentration (the size of the read-out at that concentration, not a potency): 65.6%
Compound 4: middle estimate off by 5.6 percentage points, on the low side; the range from low to high includes it.
By their numbers in this assay, from the lowest: compounds 2, 1, 3 and 4 (each within the scatter of the next, the first and the last beyond it).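

Fluoro on the phenoxy ester is now read directly, with the acetamidomethyl group held fixed, and phenyl to 3-fluorophenyl barely registers in this assay (a number 2.1 percentage points higher from compound 3 to compound 4 (within the scatter)). With the 3-fluorophenoxy ester held fixed, the group on the core does register: acetyl on the amine nitrogen gives a modest step (a number 20.3 percentage points higher from compound 2 to compound 4 (beyond the scatter)), and acetamidomethyl in place of nitro gives another (a number 12 percentage points higher from compound 1 to compound 4 (beyond the scatter)), both towards a weaker effect. No measurement available here accounts for either step.

As far as these compounds go, it remains open whether fluoro at this place would read the same on the aminomethyl or nitro compounds. A chloro or methoxy group on the phenoxy ester, or a longer acyl chain on the amine nitrogen, would show how far these two trends extend.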